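The source may report more compounds than this note shows. Statements on the series, on what has been measured and on what is new or still open speak of the compounds shown alone.

The measured compounds:

Compound 1 `COc1ccc([C@@H]2C/C(=N\O)c3c(O)cc(OCc4cn(Cc5ccccc5C)nn4)cc3O2)cc1O`: in a functional assay on RAW264.7 cells (Mus musculus) for inhibition, read by Griess assay, with stated times of 2 h and 24 h (a lower number here means a stronger inhibitor, a higher number a weaker inhibitor), compound 1 gives 18000 nM.
Compound 2 `COc1ccc([C@@H]2C/C(=N\O)c3c(O)cc(OCc4cn(Cc5ccccc5F)nn4)cc3O2)cc1O`: in this assay compound 2 gives 5710 nM.
Compound 3 `CCCCn1cc(COc2cc(O)c3c(c2)O[C@H](c2ccc(OC)c(O)c2)C/C3=N\O)nn1`: in this assay compound 3 gives 8900 nM.

Among these three numbers compound 3 holds the second highest. Its nearest neighbour is compound 2, a 1.6-fold higher number from compound 2 to compound 3 (0.19 log units; within the scatter), a gap inside the usual scatter; its furthest is compound 1, a 2.0-fold lower number from compound 1 to compound 3 (0.31 log units; beyond the scatter), a modest but real gap. The shared core is the same throughout; only the group hanging on the aromatic nitrogen of the five-membered ring changes.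

Compound 4 `COc1ccc([C@@H]2C/C(=N\O)c3c(O)cc(OCc4cn(-c5ccccc5)nn4)cc3O2)cc1O` has not yet been measured. It differs from compound 3 in one place: phenyl in place of butyl on an aromatic nitrogen.

Going by the values given here, two measured steps bear on this position. Both exchanged a benzyl-type group for butyl on that aromatic nitrogen, and they moved the number only modestly, a 2.0-fold lower number from compound 1 to compound 3 (0.31 log units; beyond the scatter), or not beyond the scatter, a 1.6-fold higher number from compound 2 to compound 3 (0.19 log units; within the scatter). A third step, a 3.2-fold lower number from compound 1 to compound 2 (0.50 log units; beyond the scatter), shows that even a change on the outer ring of such a group shifts the number modestly. Among the compounds with values here, no measured step places a ring directly on the nitrogen, so the expectation rests on the small spread seen so far.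

The estimated step in this assay from compound 3 to compound 4 is therefore a 1.1-fold lower number from compound 3 to compound 4 (0.05 log units; within the scatter), with no clear direction. Compound 4 is expected to give about 8000 nM, within a range of 3000 nM to 20000 nM.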

Compound 4, half-maximal inhibitory concentration: 6130 nM
For compound 4 the middle estimate is 1.3-fold (0.12 log units) above the measured one, and the stated range covers the measured number.
By their numbers in this assay, from the lowest: compounds 2, 4 and 3 (each within the scatter of the next); then compound 1.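

Going by these compounds alone, this is the first ring set directly on the aromatic nitrogen of the triazole, and in this assay it gives a result that cannot be told apart from the open butyl chain, with a 1.5-fold lower number from compound 3 to compound 4 (0.16 log units; within the scatter), or from the 2-fluorobenzyl group, with a 1.1-fold higher number from compound 2 to compound 4 (0.03 log units; within the scatter). Against the 2-methylbenzyl group the change is modest but real, with a 2.9-fold lower number from compound 1 to compound 4 (0.47 log units; beyond the scatter), so compound 1 alone stands apart from the other three, whose numbers all lie within the scatter of their nearest neighbours, and this position accepts a chain, a benzyl group or a directly attached phenyl with little consequence for the read-out. Nothing measured here explains why compound 1 differs from the rest.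

Still open, as far as these compounds go, is whether a methyl or a fluoro on the phenyl ring of compound 4 would separate in the way those two groups do on the benzyl ring of compound 1 and compound 2. Also open, from the compounds shown here alone, is whether a longer chain such as octyl, or a group carrying an amine or a carboxylic acid, would stay in this same narrow band on that nitrogen.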